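A few compounds are considered here, and "the series" means these few. Any claim that something is new, unique, unknown or untested is made for them only; others in the source may bear on it.

Compound 1 `CC1=C(/C=C/C(=O)/C=C/c2cccc(C(F)(F)F)c2)C(C)(C)CCC1` and compound 2 `CC1=C(/C=C/C(=O)/C=C/c2cccc([N+](=O)[O-])c2)C(C)(C)CCC1` share one core, while compound 3 `CC1=CCCC(C)(C)C1/C=C/C(=O)/C=C/c1cccc(C(F)(F)F)c1` and compound 4 `CC1=CCCC(C)(C)C1/C=C/C(=O)/C=C/c1cccc([N+](=O)[O-])c1` share another; the two cores are built from the same atoms joined differently, and the difference between them is not broken down here. In a functional assay on PC-3 cells (Homo sapiens) for cytotoxicity, read by MTT assay, with a stated time of 72 h (a higher number here means a weaker inhibitor, a lower number a stronger inhibitor), compound 1 gives 7700 nM and compound 2 gives 10000 nM. The change between them is nitro in place of trifluoromethyl on an aromatic carbon, and it produced a 1.3-fold higher number from compound 1 to compound 2 (0.11 log units; within the scatter). In this assay compound 3 gives 5200 nM. Compound 4 carries the same change on the core of compound 3: nitro in place of trifluoromethyl on an aromatic carbon. Because the earlier step was a 1.3-fold higher number from compound 1 to compound 2 (0.11 log units; within the scatter), a step of similar size is expected here, namely a 1.3-fold higher number from compound 3 to compound 4 (0.12 log units; within the scatter). Compound 4 is therefore estimated at 6800 nM in this assay, most likely falling between 3500 nM and 13000 nM.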

Compound 4, half-maximal inhibitory concentration: 2900 nM
The estimate for compound 4 lay 2.3-fold (0.37 log units) above the measured number, and the stated range ends above it.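

In this assay, nitro in place of trifluoromethyl on the core of compound 3 gives a 1.8-fold lower number from compound 3 to compound 4 (0.25 log units; within the scatter). Set beside the same change on the other core, the two steps point in opposite directions, yet the gap between them is no larger than repeat measurements could produce: the same change on two cores in this assay, a 1.3-fold higher number (0.11 log units; within the scatter) from compound 1 to compound 2 and a 1.8-fold lower number (0.25 log units; within the scatter) from compound 3 to compound 4, 2.3-fold (0.37 log units) apart, within the scatter of two such steps. Within the data shown here, this offers no sign that the core alters what the change does, but it does not show that the change carries over unchanged, as each core offers only one small step and a modest core effect could stay hidden.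

Still open, as far as these compounds go, is how other groups on this aromatic carbon, such as an amine or a carboxylic acid, would behave. Also open, from the compounds shown here alone, is whether any of them would give a step that stands clear of the scatter.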